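Furan-2-yl to furan-3-yl: a small swap

The source may hold more compounds than are shown below. What is called first, only, known or untested is meant among the compounds shown, and "the series" means these compounds.

Of the compounds shown here, three have so far been tested in a functional assay on T47D cells (Homo sapiens) for inhibition, read by CCK-8 assay and cell counting, with a stated time of 2 days; a lower number here means a stronger inhibitor, a higher number a weaker inhibitor. There, compound 1 `O=C(/C=C/c1ccco1)c1cccc(OCC2CO2)c1` gives 22700 nM, compound 2 `O=C(/C=C/c1cccs1)c1cccc(OCC2CO2)c1` gives 14600 nM and compound 3 `O=C(/C=C/c1ccco1)c1ccc(OCC2CO2)cc1` gives 17700 nM. The value of compound 3 lies within the usual scatter of both other values, so these numbers set no order among the three.

The next candidate, compound 4 `O=C(/C=C/c1ccoc1)c1ccc(OCC2CO2)cc1`, has furan-3-yl in place of furan-2-yl on a double-bonded chain carbon bound to a double-bonded chain carbon. Compounds 3 and 4 have the same atoms, joined differently.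

Among the measured compounds shown here, only one measured step bears on this, and only indirectly. It is a 1.6-fold lower number from compound 1 to compound 2 (0.19 log units; within the scatter), where a different ring replaces furan-2-yl at that same place. That step stays within the scatter, so no step beyond the scatter is expected in this assay. The estimated step is a 1.0-fold higher number from compound 3 to compound 4 (0.01 log units; within the scatter). For compound 4 the expected value is 18000 nM, with an estimated range from 9000 nM to 36000 nM.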

Compound 4, half-maximal inhibitory concentration: 20600 nM
For compound 4 the middle estimate is 1.1-fold (0.06 log units) below the measured one; the range from low to high includes it.
By their numbers in this assay, from the lowest: compounds 2, 3, 4 and 1 (each within the scatter of the next).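

In this assay, among the compounds shown here, the step with a 1.2-fold higher number from compound 3 to compound 4 (0.07 log units; within the scatter) is the first that keeps the same ring at this place and changes only which ring carbon joins the chain, and this reattachment of the furan leaves the two values within the scatter. Together with a 1.6-fold lower number from compound 1 to compound 2 (0.19 log units; within the scatter) in the other pair, it means that both ring changes shown on a double-bonded chain carbon bound to a double-bonded chain carbon stay within the scatter, although each was read on a different parent compound. No supporting data bear on this result.

Every group shown at this place is a five-membered aromatic ring, so it remains open how a phenyl ring, a pyridine ring or an amine on a longer chain would read here. Also open, as far as these compounds go, is whether furan-3-yl would give a similar result on the core of compound 1.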